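The compounds below may be only part of what the source reports. "The series", "measured", "known", "first", "only" and "open" are said of these compounds alone.

Compound 1, with the structure `CCN(CC)CN1C(=O)/C(=N/NC(=S)Nc2ccc(Cl)cc2)c2ccccc21`, was tested in an ADME assay on HEL cells (Homo sapiens) for cytotoxicity (on this read-out lower numbers stand for higher toxicity in this test and higher numbers for lower toxicity in this test), and there compound 1 gives 100000 nM. Compound 2, with the structure `CCN(CC)CN1C(=O)/C(=N/NC(=S)Nc2ccc(C)cc2)c2cc(Cl)ccc21`, was tested in the same way, and in this assay compound 2 gives 100000 nM. Compound 2 thus stands level with compound 1 at the digits recorded; the two values sit within the scatter of one another, and nothing separates them. Compound 3, with the structure `CCN(CC)CN1C(=O)/C(=N/NC(=S)Nc2ccc(Cl)cc2)c2cc(Cl)ccc21`, has not yet been measured in this assay. It differs from compound 2 in one place: chloro in place of methyl on an aromatic carbon. Going by the values given here, no measured pair shows what such a change does in this assay, so the size of the step it brings is unknown. Given that both compound 1 and compound 2 give the same value, the step from compound 2 to compound 3 is expected to be no change at the digits printed from compound 2 to compound 3 (within the scatter), that is, none beyond the scatter. Compound 3 is therefore estimated at 100000 nM, with a range from 50000 nM to 200000 nM.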

Compound 3, minimum cytotoxic concentration: 100000 nM
Compound 3: the middle estimate sits on the measured number at the digits printed; the range from low to high includes it.
By their numbers in this assay, from the lowest: compounds 1, 2 and 3 (each within the scatter of the next).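

In this assay, going by these compounds alone, the change from 4-methylphenyl to 4-chlorophenyl gives no change at the digits printed from compound 2 to compound 3 (within the scatter) and so provides the first measured pair for chloro in place of methyl at this position, on an aromatic carbon para to a large group. Chloro in place of hydrogen on an aromatic carbon gives no change at the digits printed from compound 1 to compound 3 (within the scatter) and adds a second single change to the series, with the read-out again unmoved. No supporting measurement here explains why either change leaves the value where it stands.

These compounds leave open whether an amine or a carboxylic acid in place of chloro at this position would shift the read-out. They also cannot show whether either step would look the same on a different core.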